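Fluoro to Chloro Swap Seen in Two Matched Pairs

The compounds below may be only part of what the source reports. "The series", "measured", "known", "first", "only" and "open" are said of these compounds alone.

Compound 1 `COc1cc(/C=C2\CN(C)C/C(=C\c3ccc(F)cc3)C2=O)cc(OC)c1OC` and compound 2 `COc1cc(/C=C2\CN(C)C/C(=C\c3ccc(Cl)cc3)C2=O)cc(OC)c1OC` share one core and differ at a single halogen. In a functional assay on THP-1 cells (Homo sapiens) for cytotoxicity, read by MTT assay, with a stated time of 24 h (a higher number here means a weaker inhibitor, a lower number a stronger inhibitor), compound 1 gives 6130 nM, and compound 2 gives 7200 nM. The structural change between them is chloro in place of fluoro on an aromatic carbon and the step it made is a 1.2-fold higher number from compound 1 to compound 2 (0.07 log units; within the scatter).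

Compound 3 `CN1C/C(=C\c2ccc(F)cc2)C(=O)/C(=C/c2cccc([N+](=O)[O-])c2)C1` rests on a second core; the difference between the two cores is not broken down here. In this assay compound 3 gives 7160 nM, a number within the scatter of both compound 2 and compound 1. Compound 4 `CN1C/C(=C\c2ccc(Cl)cc2)C(=O)/C(=C/c2cccc([N+](=O)[O-])c2)C1` has not yet been measured. It differs from compound 3 by chloro in place of fluoro on an aromatic carbon, the same change, at a place described in the same words, as between compound 1 and compound 2; it occurs twice among these four compounds.

The step from compound 3 to compound 4 is expected to be a 1.2-fold higher number from compound 3 to compound 4 (0.06 log units; within the scatter) because a 1.2-fold higher number from compound 1 to compound 2 (0.07 log units; within the scatter) stayed within the scatter. Compound 4 is therefore estimated at 8300 nM, with a likely range from 4500 nM to 15000 nM.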

Compound 4, half-maximal inhibitory concentration: 7870 nM
Compound 4: the middle estimate sits 1.1-fold (0.02 log units) above what was measured, and the stated range covers the measured number.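

In this assay, the change from 4-fluorophenyl to 4-chlorophenyl on the second core gives a 1.1-fold higher number from compound 3 to compound 4 (0.04 log units; within the scatter) and so stays as small there as on the first core. The two steps agree within the limits of these data: the same change on two cores in this assay, a 1.2-fold higher number (0.07 log units; within the scatter) from compound 1 to compound 2 and a 1.1-fold higher number (0.04 log units; within the scatter) from compound 3 to compound 4, 1.1-fold (0.03 log units) apart, within the scatter of two such steps. This shows that the change carried across these two cores with no step beyond the scatter, but with both steps that small it does not show that the halogen has any real effect on the number, and two cores in one cell assay say nothing about how the same change would behave on a further core or in another assay.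

Still open, as far as these compounds go, is whether a group further from these two halogens, such as bromo, methoxy, trifluoromethyl or an amine, would move the number when placed on that aromatic carbon. Also open, from the compounds shown here alone, is what a carboxylic acid or a nitrile would do in place of the nitro group of compound 4.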